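This account rests on a few compounds, and the source may have more. Where it says the series, first, only, none or still open, it means among the compounds named here.

Compound 1 `CCCCN1CC(CC(=O)NO)(NS(=O)(=O)c2ccc(OCc3cc(C)nc4ccccc34)cc2)C1`: 4900000 nM
Compound 2 `Cc1cc(COc2ccc(S(=O)(=O)NC3(C(=O)NO)CN(C(=O)C(C)C)C3)cc2)c2ccccc2n1`: 17000000 nM

In a physicochemical assay for solubility, with a stated time of 24 h, tested at 30 mg/mL (on this read-out higher numbers stand for higher solubility and lower numbers for lower solubility), compound 2 has the higher of the two numbers. The gap that separates compound 2 from compound 1 is beyond the usual scatter of repeat measurements. Compound 3 `CCN(C1(C(=O)NO)CN(C(=O)C(C)C)C1)S(=O)(=O)c1ccc(OCc2cc(C)nc3ccccc23)cc1` is compound 2 with a single change: ethyl in place of hydrogen on a sulfonamide nitrogen. Within the data shown here, no measured pair shows this change on its own, so any expectation here is loose. Among the measured compounds shown here, the only guide is the spread of the two measured values, with compound 1 at 4900000 nM and compound 2 at 17000000 nM. A slight fall is expected, probably not beyond the scatter, though a larger move either way would be no surprise. The estimated change is a 1.7-fold lower number from compound 2 to compound 3 (0.23 log units; within the scatter). For compound 3 the expected value is 10000000 nM, with an estimated range of 3000000 nM to 35000000 nM.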

Compound 3, solubility: 44000000 nM
For compound 3 the middle estimate is 4.4-fold (0.64 log units) below the measured one; the whole stated range lies below it.
By their numbers in this assay, from the lowest: compound 1; then compound 2; then compound 3.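

Replacing hydrogen with ethyl on a sulfonamide nitrogen gives, in this assay, a 2.6-fold higher number from compound 2 to compound 3 (0.41 log units; beyond the scatter). Among these compounds, this is the first measured pair in which a single change stands alone, and it shows that the hydrogen on this nitrogen can be replaced without lowering the number. It also shows that a small group with no ring, no hydrogen-bond donors and no hydrogen-bond acceptors can move the number beyond the scatter at this place, and no measurement shown here accounts for the rise.

On these data alone, whether methyl, a longer chain such as propyl, or a chain ending in an amine or a carboxylic acid on the same nitrogen would raise the number further or bring it back down remains open. As far as these compounds go, this step also rests on one pair, so whether ethyl would have the same effect on the core of compound 1 is unknown.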